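Phenyl for thiophen-2-yl at the aromatic carbon of the core

This account rests on a few compounds, and the source may have more. Where it says the series, first, only, none or still open, it means among the compounds named here.

Compound 3 `COc1ncnc2c1c(-c1cccs1)cn2[C@@H]1O[C@H](CO)[C@@H](O)[C@H]1O` gives 80 nM in a functional assay on HCT-116 cells (Homo sapiens), read by MTT assay, with a stated time of 72 h (on this read-out higher numbers stand for weaker inhibition and lower numbers for stronger inhibition), the lowest of the two numbers in hand; its nearest neighbour is compound 1 `COc1ncnc2c1c(-c1ccsc1)cn2[C@@H]1O[C@H](CO)[C@@H](O)[C@H]1O`, which gives 120 nM, and the pair sit within the scatter of each other. Among the measured compounds shown here, the only step measured within this set is a 1.5-fold lower number from compound 1 to compound 3 (0.18 log units; within the scatter). Compound 2 `CSc1ncnc2c1c(-c1ccccc1)cn2[C@@H]1O[C@H](CO)[C@@H](O)[C@H]1O` gives > 20000 nM, which is a limit of the assay and not a number (the limit of > 20000 nM in this assay, at which 1 of the 3 values shown sits). Compound 4 `COc1ncnc2c1c(-c1ccccc1)cn2[C@@H]1O[C@H](CO)[C@@H](O)[C@H]1O` is not yet measured. It differs from compound 3 in one place: phenyl in place of thiophen-2-yl on an aromatic carbon. For the measured compounds named here, no measured step bears directly on this exchange; the one step in hand swaps two thiophenyl rings and lies within the scatter, and compound 2, the only compound carrying a phenyl, differs from compound 4 elsewhere as well, so it shows no clean step. The expectation is therefore a modest weakening, with wide uncertainty: for compound 4 the estimate is 250 nM, range 60 nM to 3000 nM, expected as a step of a 3.1-fold higher number from compound 3 to compound 4 (0.49 log units; beyond the scatter).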

Compound 4, half-maximal inhibitory concentration: > 20000 nM
Compound 4 gave a limit, no number (the forecaster's own chance of this, stated with the estimate: 15%); middle value at least 80-fold (1.90 log units) from the limit.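

Phenyl in place of thiophen-2-yl gives an at least 250-fold higher number from compound 3 to compound 4 (2.39 log units; beyond the scatter), and phenyl in place of thiophen-3-yl gives an at least 160-fold higher number from compound 1 to compound 4 (2.22 log units; beyond the scatter), while the exchange between the two thiophenyl rings stays within the scatter at a 1.5-fold lower number from compound 1 to compound 3 (0.18 log units; within the scatter). At this aromatic carbon, with methoxy held constant, the change from a five-membered aromatic ring with one hetero atom to a six-membered ring of carbon only therefore separates readable values from a limit, and the step between compound 2 and compound 4 cannot be read. Compound 4 stands at a limit and has no number in this assay, and both phenyl compounds now sit there: the limit of > 20000 nM in this assay, at which 2 of the 4 values shown sit.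

The compounds shown leave open whether a furan-2-yl or pyridin-3-yl ring at this carbon keeps a readable value. They also leave open whether an amino or hydroxyl group on the phenyl ring brings compound 4 back from the limit.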